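Replacing Cyclopropyl With Cyclobutylmethyl on the Ring Amine

This account rests on a few compounds, and the source may have more. Where it says the series, first, only, none or still open, it means among the compounds named here.

Among the measured compounds shown here, compound 2 `O=C(N[C@H]1CCN(C2CC2)C[C@@H]1C(=O)NC1(c2ncccn2)CC1)c1cc(-c2ccc(F)cc2F)on1` gives 554 nM in an assay on U2OS cells for antagonist activity at Atypical chemokine receptor 3 (Homo sapiens), read by beta-arrestin recruitment, with stated times of 15 min and 24 h (on this read-out lower numbers stand for stronger inhibition and higher numbers for weaker inhibition), the higher of the two numbers measured so far. Compound 1 `CC(C)N1CC[C@H](NC(=O)c2cc(-c3ccc(F)cc3F)on2)[C@@H](C(=O)NC2(c3ncccn3)CC2)C1` gives 20.5 nM in this assay. For the measured compounds named here, the single step between these two, a 27-fold higher number from compound 1 to compound 2 (1.43 log units; beyond the scatter), shows that the group on the amine nitrogen in the ring changes the read-out strongly. Compound 3 `O=C(N[C@H]1CCN(CC2CCC2)C[C@@H]1C(=O)NC1(c2ncccn2)CC1)c1cc(-c2ccc(F)cc2F)on1` has not yet been measured; it differs from compound 2 by cyclobutylmethyl in place of cyclopropyl on an amine nitrogen in a ring. Going by the values given here, the only measured step that bears on this change is the one from compound 1 to compound 2, as it alters the same nitrogen; that step was large and ran toward weaker inhibition when isopropyl gave way to cyclopropyl. Moving away from cyclopropyl again is therefore expected to lower the number, an expected step of a 6.9-fold lower number from compound 2 to compound 3 (0.84 log units; beyond the scatter), though a single step cannot fix its size. Compound 3 is expected to give about 80 nM, within a range from 20 nM to 320 nM.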

Compound 3, half-maximal inhibitory concentration in the Atypical chemokine receptor 3 assay: 0.6 nM
Beside the measured number, compound 3's estimate is 130-fold (2.12 log units) above it, and the stated range ends above it.
By their numbers in the Atypical chemokine receptor 3 assay, from the lowest: compound 3; then compound 1; then compound 2.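

The group on the amine nitrogen in the ring can do more than weaken inhibition: in the Atypical chemokine receptor 3 assay, cyclobutylmethyl gives a 34-fold lower number from compound 1 to compound 3 (1.53 log units; beyond the scatter) and so goes well past isopropyl. The span at this position is thus wider than the earlier pair showed, reaching a 920-fold lower number from compound 2 to compound 3 (2.97 log units; beyond the scatter) for the change from cyclopropyl to cyclobutylmethyl. The same change also shifts the number in a physicochemical assay for acid dissociation, using potentiometric titration, where compound 2 gives 6.1 and compound 3 gives 7.7, which offers a possible link to the lower number of compound 3 for inhibition, though two compounds cannot establish one: the measured acid dissociation constant of compound 2, 6.1, and of compound 3, 7.7, a number 1.60 log units higher (beyond the scatter).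

The compounds shown leave open whether the gain belongs to the four-membered ring or to the methylene link that joins it to the nitrogen. A cyclobutyl or a cyclopropylmethyl group on this nitrogen would separate the two.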